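A few compounds are considered here, and "the series" means these few. Any claim that something is new, unique, unknown or untested is made for them only; others in the source may bear on it.

Within the data shown here, in a functional assay on IGROV-1 cells (Homo sapiens) for inhibition (a lower number here means a stronger inhibitor of growth, a higher number a weaker inhibitor of growth), compound 1 `NC(=O)c1cc(Cl)ccc1NC(=O)COc1ccccc1` gives 5600 nM and compound 2 `NC(=O)c1cc(I)ccc1NC(=O)COc1ccccc1` gives 1370 nM, the lower of the two numbers so far. Among the measured compounds shown here, the one measured step, a 4.1-fold lower number from compound 1 to compound 2 (0.61 log units; beyond the scatter), is modest but beyond the scatter, and it is the exchange of chloro for iodo. Compound 3 `COc1ccc(NC(=O)COc2ccccc2)c(C(N)=O)c1` departs from compound 2 by methoxy in place of iodo on an aromatic carbon, which is methoxy in place of iodo on an aromatic carbon, meta to a carbamoyl group and para to a large group. For the measured compounds named here, no measured compound carries methoxy, so the evidence is indirect. Going by the values given here, the only available guide is that compound 1, which also lacks iodo, stands at 5600 nM. A modest rise in the number is therefore expected on leaving iodo behind. The expected change is a 3.3-fold higher number from compound 2 to compound 3 (0.52 log units; beyond the scatter). For compound 3 the estimated value is 4500 nM, with an expected range of 1500 nM to 13000 nM.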

Compound 3, concentration for 50% growth inhibition: 4750 nM
Compound 3: the middle estimate sits 1.1-fold (0.02 log units) below what was measured; the range from low to high includes it.
By their numbers in this assay, from the lowest: compound 2; then compounds 3 and 1 (each within the scatter of the next).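

In this assay, the change at this position, on an aromatic carbon para to a large group, now has two replacements for iodo to compare. Methoxy in place of iodo gives a 3.5-fold higher number from compound 2 to compound 3 (0.54 log units; beyond the scatter) and so repeats what chloro showed, while methoxy in place of chloro gives a 1.2-fold lower number from compound 1 to compound 3 (0.07 log units; within the scatter) and leaves those two groups indistinguishable in this assay, although they differ in their atoms. No measurement shown here accounts for the lower number with iodo.

What remains open is whether iodo stands alone at this position or whether bromo, which is not among these compounds, would give a similar number. A nitrile, an amine or a carboxylic acid at the same carbon is likewise untested by the compounds shown, so the reach of this result across other groups remains unknown.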